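The source may hold more compounds than are shown below. What is called first, only, known or untested is meant among the compounds shown, and "the series" means these compounds.

In a toxicity assay on THP-1 cells (Homo sapiens) for inhibition (on this read-out lower numbers stand for higher toxicity in this test and higher numbers for lower toxicity in this test), compound 1 (`COc1ccc(-c2nc3ncc(-c4ccc(F)cc4)cc3[nH]2)cc1`) gives > 100000 nM, which is a limit of the assay. Compound 2 (`COc1ccc(-c2cn(C)c(NC(=O)c3ccc(F)cc3)n2)cc1`), which carries 4-fluorophenyl on a carbonyl carbon, gives > 50000 nM, also a limit. Compound 3 (`Cn1c(-c2ccccc2Cl)cnc1NC(=O)c1ncc[nH]1`) gives > 50000 nM, again a limit, so it stands at a limit like the other two. Compound 4 (`Cn1c(-c2ccccc2Cl)cnc1NC(=O)c1ccc(F)cc1`) has 4-fluorophenyl in place of 1H-imidazol-2-yl on a carbonyl carbon. Going by the values given here, no measured step is available, and with compound 2 at > 50000 nM no change beyond the scatter is expected in this assay. The expected step is a number no higher from compound 3 to compound 4 (the limit leaves the size open). For compound 4 the estimated value is 50000 nM, with an expected range of 20000 nM to 100000 nM.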

Compound 4, half-maximal cytotoxic concentration: > 50000 nM
Compound 4 ended at the assay's limit; the forecaster's own chance of this, stated with the estimate: 80%; the middle value sits exactly at the limit.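

In this assay compound 3 and compound 4 both stand at a limit, so no step can be read between them. The compounds shown leave open whether 4-fluorophenyl in place of 1H-imidazol-2-yl on a carbonyl carbon changes the half-maximal cytotoxic concentration at all.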